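The source may hold more compounds than are shown below. What is called first, only, known or untested is meant among the compounds shown, and "the series" means these compounds.

Compound 3 `CSc1nc(NCc2ccccc2)c2ccccc2n1` gives 41500 nM in a functional assay on MCF7 cells (Homo sapiens) for cytotoxicity, read by MTT assay, with a stated time of 72 h (on this read-out higher numbers stand for weaker inhibition of growth and lower numbers for stronger inhibition of growth), and it is the second highest of three numbers, all within the scatter of one another: compound 1 `COc1ccc(CNc2nc([SeH])nc3ccccc23)cc1` gives 42700 nM, and compound 2 `CSc1nc(NCc2ccc([Se]C)cc2)c2ccccc2n1` gives 36400 nM. Compound 4 `COc1ccc(CNc2nc(SC)nc3ccccc23)cc1` is not yet measured; it differs from compound 3 by methoxy in place of hydrogen on an aromatic carbon. Among the compounds with values here, the only measured step at that place on the benzyl ring is a 1.1-fold higher number from compound 2 to compound 3 (0.06 log units; within the scatter), so a change of a small group there left the number where it was. Within the data shown here, no other measured step bears on the change. Compound 4 is therefore expected to show a step of a 1.0-fold lower number from compound 3 to compound 4 (0.02 log units; within the scatter) from compound 3, not beyond the scatter. Compound 4 is estimated at 40000 nM, with a range from 20000 nM to 80000 nM.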

Compound 4, concentration for 50% growth inhibition: 30900 nM
Compound 4: the middle estimate sits 1.3-fold (0.11 log units) above what was measured; measured number inside the range.
By their numbers in this assay, from the lowest: compounds 4, 2, 3 and 1 (each within the scatter of the next).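

Methoxy on this aromatic carbon, para to a large group, leaves the number within the scatter in this assay (a step of a 1.3-fold lower number from compound 3 to compound 4 (0.13 log units; within the scatter)), and the same holds when it replaces the selenium-bearing group of compound 2 (a 1.2-fold lower number from compound 2 to compound 4 (0.07 log units; within the scatter)). On the other changed aromatic carbon, the sulfur-bearing group in place of one selenium atom also stays within the scatter (a 1.4-fold lower number from compound 1 to compound 4 (0.14 log units; within the scatter)). Nothing available accounts for these numbers. On these data alone, whether an amine, a carboxylic acid or a longer chain at the first of these places would move the number beyond the scatter stays open.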